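The source may report more compounds than this note shows. Statements on the series, on what has been measured and on what is new or still open speak of the compounds shown alone.

In a functional assay on K562 cells (Homo sapiens) for cytotoxicity, read by MTT assay, with a stated time of 48 h (a lower number here means a stronger inhibitor, a higher number a weaker inhibitor), compound 1 `NC(=O)CC[C@H](NS(=O)(=O)c1ccc([N+](=O)[O-])cc1)C(=O)O` gives only a limit, > 500000 nM. Compound 2 `CNC(=O)CC[C@H](NS(=O)(=O)c1ccc([N+](=O)[O-])cc1)C(=O)O` also gives only a limit, > 500000 nM. Compound 3 `CCNC(=O)CC[C@H](NS(=O)(=O)c1ccc([N+](=O)[O-])cc1)C(=O)O` likewise gives only a limit, > 500000 nM, so its place on the scale is not a true number. All the evidence so far is the limit of > 500000 nM in this assay, at which 3 of the 3 values shown sit.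

Compound 4 `CC(C)NC(=O)CC[C@H](NS(=O)(=O)c1ccc([N+](=O)[O-])cc1)C(=O)O` differs from compound 3 by one change, ethyl to isopropyl: methyl in place of hydrogen on a saturated chain carbon bound to an amide-type nitrogen and a saturated chain carbon. The closest measured change is a step that the two limits leave unreadable from compound 2 to compound 3. The other two, a step that the two limits leave unreadable from compound 1 to compound 2 and a step that the two limits leave unreadable from compound 1 to compound 3, are no clearer, so no measured size carries over. No shift in either direction beyond the scatter is therefore expected in this assay, and the expected change is a number no higher from compound 3 to compound 4 (the limit leaves the size open). Compound 4 is estimated at 500000 nM, with an expected range from 200000 nM to 1000000 nM.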

Compound 4, half-maximal inhibitory concentration: 19800 nM
The estimate for compound 4 lay 25-fold (1.40 log units) above the measured number, and the stated range ends above it.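

On the amide-type nitrogen, isopropyl is the only group shown that gives a true number in this assay: methyl in place of hydrogen on the saturated chain carbon brings an at least 25-fold lower number from compound 3 to compound 4 (1.40 log units; beyond the scatter). Isopropyl in place of methyl gives an at least 25-fold lower number from compound 2 to compound 4 (1.40 log units; beyond the scatter), and isopropyl in place of hydrogen gives an at least 25-fold lower number from compound 1 to compound 4 (1.40 log units; beyond the scatter). The steps among the other three compounds cannot be read, and their values remain limits: the limit of > 500000 nM in this assay, at which 3 of the 4 values shown sit.

The compounds shown leave open how a longer chain, such as butyl, or a cyclohexyl ring on that nitrogen would read. They also leave open how far the number can fall with further groups there.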